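Fluorinated thiophene core with alkoxy chains on the pendant phenyl

A few compounds are considered here, and "the series" means these few. Any claim that something is new, unique, unknown or untested is made for them only; others in the source may bear on it.

Measured compounds:
compound 1, `CC#C[C@@H](Cc1nnn[nH]1)c1ccc(OCc2ccc3sc(F)c(-c4ccccc4C)c3c2)cc1`: 15 nM
compound 2, `CC#C[C@@H](Cc1nnn[nH]1)c1ccc(OCc2ccc3scc(-c4ccc(OCCCS(C)(=O)=O)cc4C)c3c2)cc1`: 12 nM
compound 3, `CC#C[C@@H](Cc1nnn[nH]1)c1ccc(OCc2ccc3scc(-c4cc(OCCOC)ccc4C)c3c2)cc1`: 85 nM

In a functional assay on cells for agonist activity at Free fatty acid receptor 1 (Homo sapiens), read by FLIPR and calcium flux (a higher number here means that more compound is needed for the effect, a lower number that less compound is needed), compound 1 gives 15 nM. Among the three numbers it stands second highest; its nearest neighbour is compound 2, whose value of 12 nM lies within the scatter of it, while compound 3 with 85 nM lies beyond the scatter on the weaker side.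

Compound 4, `CC#C[C@@H](Cc1nnn[nH]1)c1ccc(OCc2ccc3sc(F)c(-c4ccc(OCCOC)cc4C)c3c2)cc1`, is not yet measured. It arises from compound 1 by 2-methoxyethoxy in place of hydrogen on an aromatic carbon. Compound 3 also carries a 2-methoxyethoxy group and gives 85 nM; compound 2 carries a different chain on the same phenyl and gives 12 nM. For the measured compounds named here, no step between measured compounds isolates the change in question. The expectation for compound 4 is therefore a step of a 1.1-fold lower number from compound 1 to compound 4 (0.03 log units; within the scatter) in this assay, essentially none beyond the scatter. Compound 4 is estimated at 14 nM, with a range from 6 nM to 35 nM.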

Compound 4, half-maximal effective concentration: 18 nM
The estimate for compound 4 lay 1.3-fold (0.11 log units) below the measured number, and the stated range covers the measured number.
By their numbers in this assay, from the lowest: compounds 2, 1 and 4 (each within the scatter of the next); then compound 3.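

In this assay, 2-methoxyethoxy in place of hydrogen on the aromatic carbon para to a large group and meta to the methyl group gives a 1.2-fold higher number from compound 1 to compound 4 (0.08 log units; within the scatter). The step lies within the scatter, so compound 1 and compound 4 cannot be told apart, and this position on the 2-methylphenyl ring carries the chain with no readable loss in this assay. For the compounds shown here, this is the first step that isolates one change; no measured property bears on the reason for this outcome.

On these data alone, the steps linking compound 2 and compound 3 to the others cannot be read, as each pair differs in more than one place, so the role of the fluorine on the core stays open. Also open, as far as these compounds go, is whether an amine, a carboxylic acid or a longer chain at this position would give the same result.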